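The source may report more compounds than this note shows. Statements on the series, on what has been measured and on what is new or still open speak of the compounds shown alone.

Measured in a functional assay on SW1990 cells (Homo sapiens) for cytotoxicity; on this read-out higher numbers stand for weaker inhibition and lower numbers for stronger inhibition:
- Compound 1 `C/C=C/C1=CC2=C(CO1)C(=O)[C@](C)(O)[C@H](OC(=O)c1c(C)cc(O)cc1O)C2`: 51000 nM
- Compound 2 `C/C=C/C1=CC2=C(CO1)C(=O)[C@](C)(O)[C@H](OC(=O)c1c(C)cc(O)c(O)c1OC)C2`: 26000 nM

In this assay, compound 2, at 26000 nM, lies within the usual scatter of compound 1, at 51000 nM, so neither stands apart. Compound 3 `CCCC1=CC2=C(CO1)C(=O)[C@](C)(O)[C@H](OC(=O)c1c(C)cc(O)c(O)c1OC)C2` keeps the rest of compound 2 but carries propyl in place of prop-1-en-1-yl on a double-bonded ring carbon. Going by the values given here, no measured pair shows this change, so the expectation is only a rough one: no shift beyond the scatter in this assay, with an expected 1.2-fold higher number from compound 2 to compound 3 (0.06 log units; within the scatter). Compound 3 is estimated at 30000 nM, with an expected range from 11000 nM to 70000 nM.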

Compound 3, half-maximal inhibitory concentration: 53000 nM
Beside the measured number, compound 3's estimate is 1.8-fold (0.25 log units) below it, within the range that was stated.
By their numbers in this assay, from the lowest: compounds 2, 1 and 3 (each within the scatter of the next, the first and the last beyond it).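

In this assay, propyl in place of prop-1-en-1-yl gives a 2.0-fold higher number from compound 2 to compound 3 (0.31 log units; beyond the scatter) and so weaker inhibition, a modest step only just beyond the scatter. Going by these compounds alone, this is the first reading at this ring carbon next to the ring oxygen, and it suggests that the chain's double bond can go at only a small cost. Nothing measured here gives a reason for the shift. As far as these compounds go, whether the same change would act alike on the ester of compound 1 stays open. So does the effect of a longer chain, or of an amine, at this place.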